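The source may hold more compounds than are shown below. What is called first, only, known or untested is meant among the compounds shown, and "the series" means these compounds.

Measured so far:
- compound 1, `NS(=O)(=O)c1ccc(NC(=O)NCc2ccncc2)cc1`: 14300 nM
- compound 2, `CCOC(=O)c1ccc(NC(=O)NCc2ccnnc2)cc1`: a limit only, > 100000 nM
- compound 3, `O=C(NCc1cnco1)Nc1ccc(S(=O)(=O)c2cccc(OC(F)(F)F)c2)cc1`: 70 nM

All three were run in an assay on isolated protein for activation of Nicotinamide phosphoribosyltransferase (Homo sapiens); a higher number here means that more compound is needed for the effect, a lower number that less compound is needed. Among the two numbers, compound 1 has the higher one; compound 3 sits far lower, well beyond the scatter. Compound 2 gives no number, only the limit of the limit of > 100000 nM in this assay, at which 1 of the 3 values shown sits.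

The next compound, compound 4, `CCN(CC)S(=O)(=O)c1ccc(NC(=O)NCc2ccncc2)cc1`, keeps the core of compound 1 and alters the sulfonyl end: diethylamino in place of amino on a sulfonyl sulfur. Within the data shown here, no pair of measured compounds shows this change, so its size can only be guessed from the values at hand. Compound 3, which carries a larger substituent on the sulfonyl sulfur, gives 70 nM, and compound 1 with the bare sulfamoyl gives 14300 nM; on that basis a step toward lower numbers, of modest to moderate size, is expected for compound 4 in this assay, a 2.9-fold lower number from compound 1 to compound 4 (0.46 log units; beyond the scatter). For compound 4 the estimate is 5000 nM, within a range of 1000 nM to 25000 nM.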

Compound 4, half-maximal effective concentration: 384 nM
Beside the measured number, compound 4's estimate is 13-fold (1.11 log units) above it; measured number outside the range, below it.
By their numbers in this assay, from the lowest: compound 3; then compound 4; then compound 1. At a limit, above all of these: compound 2.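

In this assay, among these compounds, the change from amino to diethylamino on a sulfonyl sulfur brings a 37-fold lower number from compound 1 to compound 4 (1.57 log units; beyond the scatter) and is the first change that can be read with the rest of the structure held fixed. This position therefore responds strongly, and the bare sulfamoyl is not required: the hydrogen-bond donor of the amino group leaves with the change, and the number still falls. No measurement at hand gives a reason for the size of this step.

This single step cannot separate the added carbons from the lost hydrogen-bond donor; methylamino, dimethylamino or a cyclic amine such as piperidine on the same sulfur would bear on that. Also open, from the compounds shown here alone, is whether the trend continues with longer chains on that nitrogen, such as dibutylamino, or stops at diethylamino.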